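The source may hold more compounds than are shown below. What is called first, only, known or untested is meant among the compounds shown, and "the series" means these compounds.

Measured in a functional assay on MDA-MB-468 cells (Homo sapiens) for antiproliferative activity, read by MTT assay, with a stated time of 48 h; on this read-out higher numbers stand for weaker inhibition and lower numbers for stronger inhibition:
- compound 1 `CN(C)CCNc1cc2c(cn1)cc(NC(=O)c1ccc(N)cc1)c(=O)n2C`: 20400 nM
- compound 2 `CN(C)CCNc1cc2c(cn1)cc(NC(=O)c1ccc(Cl)cc1)c(=O)n2C`: 1640 nM

Of these two, compound 2 has the lower number, 1640 nM. The next member of the series is compound 3 `CN(C)CCNc1cc2c(cn1)cc(NC(=O)c1ccncc1)c(=O)n2C`, still to be measured in this assay. It carries pyridin-4-yl in place of 4-chlorophenyl on a carbonyl carbon.

Within the data shown here, one measured step bears on this change: a 12-fold lower number from compound 1 to compound 2 (1.09 log units; beyond the scatter), a large step beyond the scatter, with chloro in place of amino on an aromatic carbon. It shows that the number can move strongly with a change in this part of the molecule. Compound 3 also lacks the chloro, so a move back towards weaker inhibition is expected. Among the measured compounds shown here, the evidence is thin, though, as no measured compound has a ring with a hetero atom, and the full size of the earlier step is not assumed. The expected change is a 3.7-fold higher number from compound 2 to compound 3 (0.56 log units; beyond the scatter). For compound 3 the estimate is 6000 nM, with an expected range of 1800 nM to 20000 nM.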

Compound 3, half-maximal inhibitory concentration: 8360 nM
The estimate for compound 3 lay 1.4-fold (0.14 log units) below the measured number, within the range that was stated.
By their numbers in this assay, from the lowest: compound 2; then compound 3; then compound 1.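

In this assay, the first ring with a hetero atom at this position gives a 5.1-fold higher number from compound 2 to compound 3 (0.71 log units; beyond the scatter) and so does not match the 4-chlorophenyl of compound 2. Against the 4-aminophenyl of compound 1, the same pyridin-4-yl gives a 2.4-fold lower number from compound 1 to compound 3 (0.39 log units; beyond the scatter) as its step, so the position is not a simple switch between chloro and no chloro: a group without the chloro can still differ from another group without it, and all three compounds now stand apart beyond the scatter, with compound 2 lowest, compound 3 in the middle and compound 1 highest. Nothing measured here accounts for this order or for the size of either step.

Still open, as far as these compounds go, is where an unsubstituted phenyl, a 4-methoxyphenyl or a pyridin-3-yl on the carbonyl carbon would fall in this order, and so whether the hetero atom or the missing substituent matters more for compound 3. Also open, from the compounds shown here alone, is whether the order of these three groups holds when the shared core carries a different amine or a longer chain in place of its present side chain.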